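A few compounds are considered here, and "the series" means these few. Any claim that something is new, unique, unknown or untested is made for them only; others in the source may bear on it.

Working notes on the series: plasma protein binding.

Compound 1, `Cc1noc(-c2ccc(O[C@H]3CCC[C@H](C(=O)O)C3)cc2)c1COC(=O)N(C)C1CCCC1`, is the reference point of this set. In an ADME assay on the whole organism (plasma, Rattus norvegicus, strain Sprague-Dawley) for protein binding, read by LC-MS, with a stated time of 24 h (on this read-out higher numbers stand for a larger free fraction and lower numbers for a smaller free fraction), compound 1 gives 0.002, the lowest of the three numbers obtained so far. Compound 2, `CN(C(=O)OCc1c(-c2ccc(O[C@H]3CCC[C@H](C(=O)O)C3)cc2)cnn1C)C1CCCC1`, gives 0.009 in this assay, and compound 3, `Cc1noc(-c2ccc(O[C@H]3CCC[C@H](C(=O)O)C3)cn2)c1COC(=O)N(C)C1CCCC1`, gives 0.009. The gap from compound 1 to each of these two lies beyond the usual scatter of the measurement, so compound 1 is the most tightly bound member of the measured set, while compounds 2 and 3 sit at the same level as each other. Among the measured compounds shown here, no pair of measured compounds differs in a single place, so no step within the measured set can be read off directly.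

Compound 4, `Cc1noc(-c2ccc(O[C@H]3CCC[C@H](C(=O)O)C3)cc2)c1CNC(=O)OCc1ccccc1`, has not yet been measured in this assay. Relative to compound 1 the change is a group of 11 heavy atoms (8 carbon, 1 nitrogen, 2 oxygen; one six-membered aromatic ring of carbon only) in place of a group of 10 heavy atoms (7 carbon, 1 nitrogen, 2 oxygen; one five-membered non-aromatic ring of carbon only), on a saturated chain carbon bound to an aromatic carbon. For the measured compounds named here, no measured pair shows the effect of such a change, so the expectation rests on the position of compound 1 alone. Compound 4 is expected to remain a tightly bound compound, with the step of a 1.5-fold higher number from compound 1 to compound 4 (0.18 log units; within the scatter) judged to lie within the scatter in this assay. The estimated unbound fraction for compound 4 is 0.003, in the range 0.001 to 0.008.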

Compound 4, unbound fraction: 0.004
Beside the measured number, compound 4's estimate is 1.3-fold (0.12 log units) below it; the range from low to high includes it.
By their numbers in this assay, from the lowest: compounds 1 and 4 (each within the scatter of the next); then compounds 2 and 3 (each within the scatter of the next).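

Among the compounds shown here, the exchange of a group with a five-membered non-aromatic ring of carbon only for (benzyloxycarbonyl)amino, on a saturated chain carbon bound to an aromatic carbon, provides the first single-place comparison of the series in this assay: a 2.0-fold higher number from compound 1 to compound 4 (0.30 log units; within the scatter) is what this change gives. At this position, then, compound 1 and compound 4 cannot be told apart on the free fraction, even though the change brings in a six-membered aromatic ring of carbon only and 1 hydrogen-bond donor where the leaving group has 0, and both compounds stay on the tightly bound side of the set, apart from the printed values of compounds 2 and 3. No measurement at hand accounts for this outcome.

As far as these compounds go, the ring and the hydrogen-bond donor enter together in this single step, so what each contributes on its own stays open, and a single comparison at one position cannot show how far the result extends. From the compounds shown here alone, whether an amine, a carboxylic acid or a longer chain on the same saturated chain carbon would leave the free fraction at this level also stays open, as does the effect of (benzyloxycarbonyl)amino on the cores of compounds 2 and 3.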